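Aryl variation on the aromatic nitrogen: outlook for compound 4

The source may hold more compounds than are shown below. What is called first, only, known or untested is meant among the compounds shown, and "the series" means these compounds.

Compound 1 `CC(C)=CCC/C(C)=C/CC/C(C)=C/CC[C@@H]1[C@@]2(C)CC/C(=N\OCc3cn(-c4ccc(Cl)cc4)nn3)C(C)(C)[C@@H]2CC[C@@]1(C)O`, compound 2 `CC(C)=CCC/C(C)=C/CC/C(C)=C/CC[C@@H]1[C@@]2(C)CC/C(=N\OCc3cn(-c4cccc([N+](=O)[O-])c4)nn3)C(C)(C)[C@@H]2CC[C@@]1(C)O` and compound 3 `COc1cc(OC)c(-n2cc(CO/N=C3\CC[C@]4(C)[C@@H](CC/C=C(\C)CC/C=C(\C)CCC=C(C)C)[C@](C)(O)CC[C@H]4C3(C)C)nn2)c(OC)c1` share one core and differ only in the aryl group on the aromatic nitrogen. In a functional assay on A549 cells (Homo sapiens) for cytotoxicity, read by MTT assay, with a stated time of 48 h (on this read-out higher numbers stand for weaker inhibition and lower numbers for stronger inhibition), compound 1 gives 12300 nM, compound 2 gives 14800 nM and compound 3 gives 8120 nM. Compound 1 thus holds the second highest of the three numbers, all three lying within the scatter of one another. The measured steps of a 1.2-fold higher number from compound 1 to compound 2 (0.08 log units; within the scatter), a 1.5-fold lower number from compound 1 to compound 3 (0.18 log units; within the scatter) and a 1.8-fold lower number from compound 2 to compound 3 (0.26 log units; within the scatter) are each within the scatter. Compound 4 `CC(C)=CCC/C(C)=C/CC/C(C)=C/CC[C@@H]1[C@@]2(C)CC/C(=N\OCc3cn(-c4ccc(F)c(F)c4F)nn3)C(C)(C)[C@@H]2CC[C@@]1(C)O` carries 2,3,4-trifluorophenyl in place of 4-chlorophenyl on an aromatic nitrogen. All three measured aryl changes bear on this step and none moved the number beyond the scatter. Compound 4 is therefore expected to show a 1.0-fold lower number from compound 1 to compound 4 (0.01 log units; within the scatter), no step beyond the scatter. Compound 4 is estimated at 12000 nM, within 6000 nM to 25000 nM.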

Compound 4, half-maximal inhibitory concentration: 26900 nM
For compound 4 the middle estimate is 2.2-fold (0.35 log units) below the measured one; measured number outside the range, above it.
By their numbers in this assay, from the lowest: compounds 3, 1, 2 and 4 (each within the scatter of the next, the first and the last beyond it).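

In this assay this position no longer looks indifferent to the aryl group: 2,3,4-trifluorophenyl gives a 2.2-fold higher number from compound 1 to compound 4 (0.34 log units; beyond the scatter) and a 3.3-fold higher number from compound 3 to compound 4 (0.52 log units; beyond the scatter) as modest steps. Compound 2 goes against a clean separation, with a 1.8-fold higher number from compound 2 to compound 4 (0.26 log units; within the scatter) as the remaining step. Nothing available explains these differences. The compounds shown leave open how an aryl group bearing an amine or a carboxylic acid would read, and whether a longer chain in place of the aryl group would stay in this range.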